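This account rests on a few compounds, and the source may have more. Where it says the series, first, only, none or still open, it means among the compounds named here.

Of the compounds shown here, two have so far been measured in a functional assay on MCF7 cells (Homo sapiens) for cytotoxicity, read by MTT assay, with a stated time of 48 h; on this read-out higher numbers stand for weaker inhibition and lower numbers for stronger inhibition. Compound 1, `COc1cc(N2C(=S)SCC2(O)c2ccc(Br)cc2)cc(OC)c1OC`, gives 16.5 ug/mL in this assay. Compound 2, `COc1cc(-n2c(-c3ccccc3)csc2=S)cc(OC)c1OC`, is built differently around the shared core. For compound 2 this assay returns only a limit, > 100 ug/mL, and not a number. Among the two values shown, this reading corresponds to the limit of > 100 ug/mL in this assay, at which 1 of the 2 values shown sits.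

Compound 3, `COc1cc(-n2c(-c3ccc(F)cc3)csc2=S)cc(OC)c1OC`, differs from compound 2 in one place: fluoro in place of hydrogen on an aromatic carbon. Among the compounds with values here, no step between two measured compounds is available, so the effect of that change can be judged only from where compound 2 stands. Since compound 2 already sits at the limit of this assay, the step of a number no higher from compound 2 to compound 3 (the limit leaves the size open) is expected to be none beyond the usual scatter, with no clear direction. Compound 3 is therefore estimated to give about 100 ug/mL in this assay, within a range from 40 ug/mL to 250 ug/mL, and it is expected that the assay may again report only a limit rather than a number.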

Compound 3, half-maximal inhibitory concentration: 38.5 ug/mL
Compound 3: the middle estimate sits 2.6-fold (0.41 log units) above what was measured; measured number outside the range, below it.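

In this assay, fluoro in place of hydrogen on an aromatic carbon gives an at least 2.5-fold lower number from compound 2 to compound 3 (0.41 log units; beyond the scatter). The position on the six-membered aromatic ring of carbon only, para to a large group, therefore responds to this change, and one added fluorine atom is enough to turn a limit into a number. The full size of the step remains unknown because compound 2 gives only a limit: the limit of > 100 ug/mL in this assay, at which 1 of the 3 values shown sits.

The compounds shown carry only hydrogen and fluoro at this place, leaving open how chloro, methoxy, an amine or a carboxylic acid there would read in this assay. Within the data shown here, compound 1 differs from compound 2 and compound 3 in more than one place, so no step to it can be read, and whether fluoro would have a similar effect on the core of compound 1 remains open.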